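Three measured analogues and an expected fourth

This account rests on a few compounds, and the source may have more. Where it says the series, first, only, none or still open, it means among the compounds named here.

Measured so far:
compound 1 `CCN(CC)Cc1ccc2nc(NC(=O)N/N=C/c3cn(Cc4cccc(Cl)c4)c4ccccc34)sc2c1`: 2050 nM
compound 2 `CCN(CC)Cc1ccc2nc(NC(=O)N/N=C/c3cn(Cc4ccc(C)cc4)c4ccccc34)sc2c1`: 2010 nM
compound 3 `Cc1ccc(Cn2cc(/C=N/NC(=O)Nc3nc4ccc(CN(C)C)cc4s3)c3ccccc32)cc1`: 1220 nM

The three numbers come from a functional assay on MDA-MB-231 cells (Homo sapiens) for cytotoxicity, read by MTT assay, with a stated time of 72 h; a higher number here means a weaker inhibitor, a lower number a stronger inhibitor. Compound 2 and compound 1 share a core and differ by 3-chlorophenyl in place of 4-methylphenyl on a saturated chain carbon bound to an aromatic nitrogen; the step is a 1.0-fold higher number from compound 2 to compound 1 (0.01 log units; within the scatter). Compound 2 and compound 3 differ instead by dimethylamino in place of diethylamino on a saturated chain carbon bound to an aromatic carbon, with a step of a 1.6-fold lower number from compound 2 to compound 3 (0.22 log units; within the scatter). Compound 3 stands at the lowest of the three numbers, but both gaps to it lie within the scatter, so no order among compound 1, compound 2 and compound 3 can be read from this assay; compound 1 and compound 3 are simply within the scatter of each other.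

Compound 4 `CN(C)Cc1ccc2nc(NC(=O)N/N=C/c3cn(Cc4cccc(Cl)c4)c4ccccc34)sc2c1` has not yet been measured. For the measured compounds named here, it relates to compound 3 by 3-chlorophenyl in place of 4-methylphenyl on a saturated chain carbon bound to an aromatic nitrogen, which is the same change as the one from compound 2 to compound 1, made on a core that differs from the core of compound 2 by dimethylamino in place of diethylamino on a saturated chain carbon bound to an aromatic carbon. The place of the change is the same in both pairs.

The step from compound 3 to compound 4 is expected to be a 1.0-fold higher number from compound 3 to compound 4 (0.01 log units; within the scatter), resting on the flat step a 1.0-fold higher number from compound 2 to compound 1 (0.01 log units; within the scatter) seen for the same change in the other pair. Compound 4 is therefore estimated at 1250 nM, with a plausible range from 600 nM to 2600 nM.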

Compound 4, half-maximal inhibitory concentration: 1140 nM
Beside the measured number, compound 4's estimate is 1.1-fold (0.04 log units) above it, within the range that was stated.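

In this assay, 3-chlorophenyl in place of 4-methylphenyl on a saturated chain carbon bound to an aromatic nitrogen gives a 1.1-fold lower number from compound 3 to compound 4 (0.03 log units; within the scatter), and this change carries over from the diethylamino core to the dimethylamino core with no detectable difference: the same change on two cores in this assay, a 1.0-fold higher number (0.01 log units; within the scatter) from compound 2 to compound 1 and a 1.1-fold lower number (0.03 log units; within the scatter) from compound 3 to compound 4, 1.1-fold (0.04 log units) apart, within the scatter of two such steps. Dimethylamino in place of diethylamino on a saturated chain carbon bound to an aromatic carbon gives a 1.8-fold lower number from compound 1 to compound 4 (0.25 log units; within the scatter), and it likewise reads the same with either benzyl group: the same change on two cores in this assay, a 1.6-fold lower number (0.22 log units; within the scatter) from compound 2 to compound 3 and a 1.8-fold lower number (0.25 log units; within the scatter) from compound 1 to compound 4, 1.1-fold (0.04 log units) apart, within the scatter of two such steps. This shows that both changes transfer as steps within the scatter across the four compounds, but it does not show that either change has an effect of its own on the number in this assay, nor does it test transfer for a step large enough to stand clear of the scatter.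

The compounds shown leave open whether a morpholine or a pyrrolidine in place of the dimethylamino group, or a pyridylmethyl group in place of 3-chlorobenzyl, would move the number beyond the scatter. They also leave open whether such a larger step would carry over between cores as these small steps do.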